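Pyrazole carboxylic acids on BJAB cells: a weak series

This account rests on a few compounds, and the source may have more. Where it says the series, first, only, none or still open, it means among the compounds named here.

Three compounds of the shared core carry a number or a remark in a functional assay on BJAB cells (Homo sapiens) for antiproliferative activity, with a stated time of 4 days; on this read-out higher numbers stand for an effect only at larger amounts of compound and lower numbers for an effect already at smaller amounts. Compound 1 `Cc1c(-c2cc(Cl)cc(Cl)c2)c(C(=O)O)nn1-c1nc(-c2cccnc2)c(SC(C)C)s1` is reported as "not active" (no number reported) without a single number. Compound 2 `Cc1c(-c2cc(Cl)cc(Cl)c2)c(C(=O)O)nn1-c1nc(-c2cnn(C)c2)c(SC(C)C)s1` is likewise reported as "not active" (no number reported) without a single number. Among the measured compounds shown here, compound 3 `Cc1nn(-c2nc(-c3ccc(Cl)c(Cl)c3)c(SC(C)C)s2)c(C(=O)O)c1-c1cncc(C#N)c1` is the one member with a number: in this assay compound 3 gives 20000 nM, which is the only figure and a weak one; it stands alone, since compound 1 and compound 2 gave no number at all. No change between two measured compounds is recorded, so the size of any step must be guessed. Compound 4 `Cc1cc(-c2c(C)nn(-c3nc(-c4ccc(Cl)c(Cl)c4)c(SC(C)C)s3)c2C(=O)O)cc(C)n1` is the next entry and has not yet been measured in this assay. The difference from compound 3 is 2,6-dimethylpyridin-4-yl in place of 5-cyanopyridin-3-yl on an aromatic carbon. With nothing in the series above weak activity, compound 4 is expected to stay near the value of compound 3, the step of no change at the digits printed from compound 3 to compound 4 (within the scatter) being estimated as none beyond the scatter. Compound 4 is therefore estimated at 20000 nM, with a range from 7000 nM to 60000 nM, and a fair chance that this assay again reports no number.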

Compound 4, half-maximal effective concentration: 580 nM
Compound 4: middle estimate off by 34-fold (1.54 log units), on the high side; measured number outside the range, below it.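

In this assay, 2,6-dimethylpyridin-4-yl in place of 5-cyanopyridin-3-yl on an aromatic carbon gives a 34-fold lower number from compound 3 to compound 4 (1.54 log units; beyond the scatter), so this position can move the read-out well beyond the scatter. The entering and leaving groups have the same heavy-atom count and each is a six-membered aromatic ring with one hetero atom, so the step comes without a change in those counts; the nitrile leaves and two methyl groups enter, and the attachment point on the ring also changes. Nothing measured here bears on why the number moves.

Going by these compounds, it remains open whether the methyl groups or the attachment point carries the step; pyridin-4-yl without methyl groups and 5-methylpyridin-3-yl would separate the two. Also open, on these data alone, is how an amine on the same ring would read out.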